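Replacing the 4-(methylsulfonyl)piperazin-1-yl group of compound 3

The source may hold more compounds than are shown below. What is called first, only, known or untested is meant among the compounds shown, and "the series" means these compounds.

Within the data shown here, in an ADME assay on microsomes from liver (Homo sapiens) for metabolic stability, read by LC-MS, tested at 1 uM (a higher number here means faster removal of the compound, a lower number slower removal), compound 3 (`CS(=O)(=O)N1CCN(CCCOc2ccc([C@H]3CC[C@]4(CC3)OOC3(O4)C4CC5CC(C4)CC3C5)cc2)CC1`) gives 68 mL.min-1.g-1, the only value so far that is not a limit. Compound 1 (`N[C@H]1CC[C@H](Oc2ccc([C@H]3CC[C@]4(CC3)OOC3(O4)C4CC5CC(C4)CC3C5)cc2)CC1`) gives < 7 mL.min-1.g-1, which is a limit. Compound 2 (`NC1CCN(S(=O)(=O)c2ccc([C@H]3CC[C@]4(CC3)OOC3(O4)C4CC5CC(C4)CC3C5)cc2)CC1`) gives < 7 mL.min-1.g-1, also a limit. The series thus shows (the limit of < 7 mL.min-1.g-1 in this assay, at which 2 of the 3 values shown sit). Among the measured compounds shown here, the one measured step, a step that the two limits leave unreadable from compound 1 to compound 2, has no readable size and does not cover the change to compound 4 (`NCCCCOc1ccc([C@H]2CC[C@]3(CC2)OOC2(O3)C3CC4CC(C3)CC2C4)cc1`). That change is aminomethyl in place of 4-(methylsulfonyl)piperazin-1-yl on a saturated chain carbon, three bonds along the chain from an oxygen on an aromatic ring. Compound 4 carries an amino group, as does compound 2, which gives < 7 mL.min-1.g-1, a limit. The expected change is a fall in this assay, a 5.7-fold lower number from compound 3 to compound 4 (0.75 log units; beyond the scatter), resting only on limits. For compound 4 the estimated value is 12 mL.min-1.g-1, with an expected range of 5 mL.min-1.g-1 to 35 mL.min-1.g-1.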

Compound 4, intrinsic clearance in microsomes: < 7 mL.min-1.g-1
Compound 4: no number, only a limit; the forecaster's own chance of this, stated with the estimate: 45%; middle value at least 1.7-fold (0.23 log units) away from the limit.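

In this assay, among these compounds, aminomethyl in place of 4-(methylsulfonyl)piperazin-1-yl on this saturated chain carbon gives the first step of readable size: an at least 9.7-fold lower number from compound 3 to compound 4 (0.98 log units; beyond the scatter). The steps among compounds 1, 2 and 4 cannot be read. Compounds 1, 2 and 4 all carry an amino group, and compound 3, which has none, is the only one with a number rather than a limit: the limit of < 7 mL.min-1.g-1 in this assay, at which 3 of the 4 values shown sit.

On these data alone, the change swaps the ring and the amino group at once, so it remains open which of the two goes with the lower number. A dimethylamino group or a methylsulfonylamino group on the same chain would separate them.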